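Aryl variation on the ketone side of the shared core

The source may hold more compounds than are shown below. What is called first, only, known or untested is meant among the compounds shown, and "the series" means these compounds.

Measured so far:
compound 1 `O=C(/C=C/c1ccc2c(c1)B(O)OC2)c1ccc(-c2ccccc2)cc1`: 6400 nM
compound 2 `O=C(/C=C/c1ccc2c(c1)B(O)OC2)c1cccs1`: 4600 nM

In a functional assay on MDA-MB-231 cells (Homo sapiens) for cytotoxicity, read by MTT assay, with a stated time of 48 h (a lower number here means a stronger inhibitor, a higher number a weaker inhibitor), compound 1 gives 6400 nM, the highest of the two numbers recorded. Compound 2 gives 4600 nM in this assay; the gap between the two lies within the usual scatter, so no order between them is drawn.

Compound 3 `CSc1ccc(C(=O)/C=C/c2ccc3c(c2)B(O)OC3)cc1` has not yet been measured in this assay. It differs from compound 1 by methylsulfanyl in place of phenyl on an aromatic carbon. Among the compounds with values here, no measured pair shows this exact change, so the expectation rests only on the two numbers above, which sit close together despite different ketone-side groups. In this assay the step is expected to be a 1.3-fold lower number from compound 1 to compound 3 (0.11 log units; within the scatter), that is, nothing clearly beyond the scatter, with a slight lean toward a lower number. In this assay compound 3 is expected to give about 5000 nM, with a range from 2000 nM to 12000 nM.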

Compound 3, half-maximal inhibitory concentration: 9800 nM
Compound 3: the middle estimate sits 2.0-fold (0.29 log units) below what was measured; measured number inside the range.
By their numbers in this assay, from the lowest: compounds 2, 1 and 3 (each within the scatter of the next, the first and the last beyond it).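

At this position, on an aromatic carbon para to a large group, methylsulfanyl in place of phenyl gives a 1.5-fold higher number from compound 1 to compound 3 (0.19 log units; within the scatter) in this assay. Within the data shown here, this is the only single-place step so far, and it shows that the phenyl of compound 1 can give way to a group with no ring without a shift beyond the scatter. No measurement at hand bears on the reason for this result.

Going by these compounds, whether an amine or a carboxylic acid on the same aromatic carbon would move the number beyond the scatter remains open. Also open, on these data alone, is whether a longer chain on the sulfur, or a second phenyl ring carrying methylsulfanyl, would hold the number within the scatter of compound 1.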